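Swapping an anilino for a benzyl on a sulfonyl sulfur

This account rests on a few compounds, and the source may have more. Where it says the series, first, only, none or still open, it means among the compounds named here.

Four compounds share one core built around a hydroxamic acid chain attached to a ring that carries a sulfonyl group. Compound 1 `Cc1cc(C)cc(S(=O)(=O)N2CCC(CCCC(=O)NO)CC2)c1` and compound 2 `O=C(CCCC1CCN(S(=O)(=O)c2ccccc2O)CC1)NO` belong to this set, but in a functional assay on HCT-116 cells (Homo sapiens) for inhibition, read by resazurin assay, with a stated time of 5 days (a lower number here means a stronger inhibitor of growth, a higher number a weaker inhibitor of growth), compound 1 gives "not determined" (no result reported) and compound 2 gives "not determined" (no result reported), so neither contributes a number. Compound 3 `O=C(CCCC1CCN(S(=O)(=O)Nc2ccccc2)CC1)NO` is therefore the only member with a measured result: in this assay compound 3 gives 2000 nM, and it stands alone on the numbers shown, with nothing to rank it against.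

Compound 4 `O=C(CCCC1CCN(S(=O)(=O)Cc2ccccc2)CC1)NO` has not yet been measured. It differs from compound 3 in a single place: benzyl in place of anilino on a sulfonyl sulfur. The group that leaves and the group that enters are of the same size and each carries one six-membered aromatic ring, so the change is a small rearrangement rather than an addition or removal of bulk.

Within the data shown here, no measured pair in this set isolates such a change, so there is no basis for expecting a large shift in either direction. The step from compound 3 to compound 4 is expected to be a 1.3-fold higher number from compound 3 to compound 4 (0.10 log units; within the scatter), most likely within the usual scatter. Compound 4 is estimated at 2500 nM, with a plausible range from 900 nM to 7000 nM.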

Compound 4, concentration for 50% growth inhibition: 3200 nM
For compound 4 the middle estimate is 1.3-fold (0.11 log units) below the measured one; the measured number falls inside the stated range.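

In this assay, among these compounds, the exchange of anilino for benzyl on a sulfonyl sulfur gives a 1.6-fold higher number from compound 3 to compound 4 (0.20 log units; within the scatter) and this is the first step at this place that can be read. Anilino carries a hydrogen-bond donor and benzyl carries none, yet the two compounds cannot be told apart by their growth inhibition, so on this one pair that donor makes no visible difference to the number. Nothing in the data shown explains this result, and a single pair cannot tell whether the same would hold on a different core.

The steps to compound 1 and compound 2 cannot be read, since neither has a number, so the shown data do not reveal how an aromatic ring carried directly on the sulfur compares with anilino or benzyl. Also open, from the compounds shown here alone, is whether a different group on the sulfur, such as a simple methyl or a benzyl bearing a carboxylic acid, or a longer chain leading to the hydroxamic acid, would move the number beyond the usual scatter.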